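This account rests on a few compounds, and the source may have more. Where it says the series, first, only, none or still open, it means among the compounds named here.

In a functional assay on HT-29 cells (Homo sapiens) for inhibition, read by luminescence and CellTiter-Glo, with a stated time of 12 h (on this read-out lower numbers stand for an effect already at smaller amounts and higher numbers for an effect only at larger amounts of compound), compound 1, whose structure is `CCOC(=O)c1cccc(NC(=O)Nc2cc(Oc3ccc4nc(NC(=O)C5CC5)sc4c3)ccc2F)c1`, gives 7740 nM. Within the data shown here, that is the only actual number among the three compounds measured so far, since the other two sit at a limit of the assay, as the limit of > 20000 nM in this assay, at which 2 of the 3 values shown sit, records. Compound 2, with the structure `N#Cc1c(Oc2ccc(F)c(NC(=O)c3cccc(C(F)(F)F)c3)c2)ccc2nc(NC(=O)C3CC3)sc12`, shows in this assay only the limit > 20000 nM. Compound 3, with the structure `O=C(Nc1nc2ccc(Oc3ccc(F)c(NC(=O)C4(c5cccc(C(F)(F)F)c5)CC4)c3)cc2s1)C1CC1`, likewise shows only the limit > 20000 nM. Compound 1 therefore stands alone as a measured value, and nothing in these three compounds tells how large a change a single substitution tends to bring in this assay.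

Compound 4, whose structure is `O=C(Nc1cccc(Br)c1)Nc1cc(Oc2ccc3nc(NC(=O)C4CC4)sc3c2)ccc1F`, has not yet been measured. It differs from compound 1 in one place:

bromo in place of ethoxycarbonyl on an aromatic carbon

Among the measured compounds shown here, since no measured pair that differs in one place is available here, there is no comparison to lean on. The shared core is untouched and the change is confined to the group on one aromatic ring, so the expected step from compound 1 to compound 4 is a 1.0-fold higher number from compound 1 to compound 4 (0.01 log units; within the scatter), a shift that stays within the usual scatter. On that basis compound 4 is estimated to give about 8000 nM in this assay, with a plausible range from 2500 nM to 25000 nM.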

Compound 4, half-maximal effective concentration: 440 nM
Estimate against measurement, compound 4: 18-fold (1.26 log units) above; measured number below the stated range.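

In this assay, among these compounds, replacing ethoxycarbonyl with bromo on this aromatic carbon gives an 18-fold lower number from compound 1 to compound 4 (1.25 log units; beyond the scatter), the first measured evidence of how much a single change can move the number. The shared core stays the same, and a group of 5 heavy atoms with 2 hydrogen-bond acceptors gives way to a single bromine atom with no hydrogen-bond acceptors, so this place on the ring, meta to a large group, clearly responds to what sits on it. The result records the size of the step but does not explain it, and nothing shown here gives a measured reason for it.

A single pair cannot separate the possible contributions of group size, the loss of the acceptors and the identity of bromine itself, since all of these change together in this one step. Other groups at this place, such as chloro, methyl, an amine or a carboxylic acid, would be needed to show whether the lower number is particular to bromo or is shared by other small groups.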